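The source may report more compounds than this note shows. Statements on the series, on what has been measured and on what is new or still open speak of the compounds shown alone.

Measured in a physicochemical assay for lipophilicity, measured as octanol-water partition, at pH 7.4; a higher number here means a more lipophilic compound, a lower number a more polar compound:
- Compound 1 `O=C(NCCCNC1CCCCC1)[C@H]1C[C@@H]1c1ccccc1`: 1.1; 1.1; 1.3 (3 entries)
- Compound 2 `CCN(CC)CCNC(=O)[C@H]1C[C@@H]1c1ccccc1`: 0.6
- Compound 3 `CC(C)N(CCNC(=O)[C@H]1C[C@@H]1c1ccccc1)C(C)C`: 1

Of the two compounds with a single number, compound 3 stands highest. Compound 4 `O=C(NCCN1CCCC1)[C@H]1C[C@@H]1c1ccccc1`, not yet measured, carries pyrrolidin-1-yl in place of diisopropylamino on a saturated chain carbon, two bonds along the chain from an amide-type nitrogen. For the measured compounds named here, one measured step bears on this change, at the same place, and it brought diisopropylamino in for diethylamino: a number 0.40 log units higher from compound 2 to compound 3 (beyond the scatter). With diisopropylamino leaving, a fall in this assay of similar or somewhat larger size, beyond the scatter, is expected. The expected change is a number 0.60 log units lower from compound 3 to compound 4 (beyond the scatter). For compound 4 the estimated value is 0.4, with an expected range of 0 to 0.8.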

Compound 4, distribution coefficient: 0.9
For compound 4 the middle estimate is 0.50 log units below the measured one; measured number outside the range, above it.
By their numbers in this assay, from the lowest: compounds 2, 4 and 3 (each within the scatter of the next, the first and the last beyond it).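

In this assay, pyrrolidin-1-yl on a saturated chain carbon, two bonds along the chain from an amide-type nitrogen, cannot be told from either acyclic amine: the data give a number 0.10 log units lower from compound 3 to compound 4 (within the scatter) and a number 0.30 log units higher from compound 2 to compound 4 (within the scatter). Compound 2 and compound 3 remain apart, yet compound 4 separates from neither, so the earlier step does not extend to this ring as a simple series. The spread of repeat readings for a single compound shows how closely such numbers can lie: the several entries of compound 1 in this assay, 1.1; 1.1; 1.3 (3 entries).

Whether piperidin-1-yl or morpholin-4-yl at this place would also fall among these numbers remains open.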